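Swapping the Oxygen-Linked Group for a Nitrile

The compounds below may be only part of what the source reports. "The series", "measured", "known", "first", "only" and "open" are said of these compounds alone.

Two compounds share one core and differ only in the group attached through oxygen to the fused-ring part. In a functional assay on HEK293 cells for agonist activity at Free fatty acid receptor 1 (Homo sapiens), read by fluorescence and calcium flux, with a stated time of 10 min (on this read-out higher numbers stand for an effect only at larger amounts of compound and lower numbers for an effect already at smaller amounts), compound 1 `CC#C[C@@H](CC(=O)O)c1ccc(OC[C@H]2COc3ccc(OC)cc3O2)cc1` gives 130 nM, while compound 2 `CC#C[C@@H](CC(=O)O)c1ccc(OC[C@H]2COc3ccc(OC(F)(F)F)cc3O2)cc1` gives 700 nM. Compound 2 thus stands at the higher of the two numbers, and the step of a 5.4-fold higher number from compound 1 to compound 2 (0.73 log units; beyond the scatter) shows that this position responds clearly to a change of substituent. Compound 3 `CC#C[C@@H](CC(=O)O)c1ccc(OC[C@H]2COc3ccc(C#N)cc3O2)cc1` carries cyano in place of trifluoromethoxy on an aromatic carbon. Among the compounds with values here, no measured step covers this exchange directly; the one known step only shows that a change at this site can move the number substantially. The number for compound 3 is therefore expected to fall between the two measured values, the step of a 1.8-fold lower number from compound 2 to compound 3 (0.24 log units; within the scatter) being the expected outcome. For compound 3 the estimate is 400 nM, with an expected range from 150 nM to 1200 nM.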

Compound 3, half-maximal effective concentration: 2100 nM
Compound 3: the middle estimate sits 5.3-fold (0.72 log units) below what was measured, outside the stated range (above it).
By their numbers in this assay, from the lowest: compound 1; then compound 2; then compound 3.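

In this assay the cyano group does not fall between the two oxygen-linked groups: replacing trifluoromethoxy gives a 3.0-fold higher number from compound 2 to compound 3 (0.48 log units; beyond the scatter) and replacing methoxy gives a 16-fold higher number from compound 1 to compound 3 (1.21 log units; beyond the scatter) so compound 3 has the highest number of the three. The second step is the larger of the two and is classed as large, so this single aromatic carbon can shift the number further than the first pair revealed. Nothing measured here explains why the three groups fall in this order.

Going by these compounds, whether any group at this carbon can bring the number below that of compound 1 remains open. An ethoxy group, a plain methyl or an amine in the same place would show whether the oxygen link itself matters or whether methoxy is a special case.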